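Varying the benzyl group on the shared core

The source may hold more compounds than are shown below. What is called first, only, known or untested is meant among the compounds shown, and "the series" means these compounds.

Compound 1 `O=S(=O)(NCCCNCc1ccc(C(F)(F)F)cc1)c1cc(C(F)(F)F)cc(C(F)(F)F)c1` and compound 2 `O=S(=O)(NCCCNCc1ccc(-c2ccccc2)cc1)c1cc(C(F)(F)F)cc(C(F)(F)F)c1` share one core and differ only in the benzyl group. In a functional assay on BE(2)-C cells (Homo sapiens) for inhibition, read by MTT assay, with a stated time of 72 h (a lower number here means a stronger inhibitor of growth, a higher number a weaker inhibitor of growth), compound 1 gives 2700 nM, numerically the higher of the two numbers, while compound 2 gives 2600 nM; the step of a 1.0-fold lower number from compound 1 to compound 2 (0.02 log units; within the scatter) is within the scatter. Compound 3 `COc1ccccc1CNCCCNS(=O)(=O)c1cc(C(F)(F)F)cc(C(F)(F)F)c1` carries 2-methoxyphenyl in place of 4-(trifluoromethyl)phenyl on a saturated chain carbon bound to an amine nitrogen. Within the data shown here, the single step measured at this place, a 1.0-fold lower number from compound 1 to compound 2 (0.02 log units; within the scatter), was flat, so compound 3 is expected to show no step beyond the scatter in this assay, namely no change at the digits printed from compound 1 to compound 3 (within the scatter). Compound 3 is therefore estimated at 2700 nM, within 1000 nM to 7500 nM.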

Compound 3, concentration for 50% growth inhibition: 3600 nM
For compound 3 the middle estimate is 1.3-fold (0.12 log units) below the measured one; low and high end bracket the measured number.
By their numbers in this assay, from the lowest: compounds 2, 1 and 3 (each within the scatter of the next).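

The step of a 1.3-fold higher number from compound 1 to compound 3 (0.12 log units; within the scatter) in this assay shows that this position also accommodates a different kind of group: 2-methoxybenzyl, with an oxygen and one hydrogen-bond acceptor, in place of 4-(trifluoromethyl)benzyl, with three fluorines and none. Neither the loss of trifluoromethyl nor the entry of methoxy moves the number beyond the scatter here. No evidence on hand explains this flat result.

Still open, from the compounds shown here alone, is whether an amine or a carboxylic acid on the aromatic ring, or a longer chain in place of the benzyl group, would give a step beyond the scatter.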